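Methoxy for amino on a chalcone-type pyrazole

The source may hold more compounds than are shown below. What is called first, only, known or untested is meant among the compounds shown, and "the series" means these compounds.

Compound 1 `COc1cc(-c2cc(/C=C/C(=O)c3ccc(N)cc3)[nH]n2)cc(OC)c1OC` was tested in a functional assay on T47D cells (Homo sapiens) for cytotoxicity, read by sulforhodamine B assay, with a stated time of 48 h, tested at 1 uM (on this read-out higher numbers stand for a weaker effect at the one concentration tested and lower numbers for a stronger effect), where it gives 66%; this is the lowest of the three numbers at hand. Compound 2 `COc1ccc(-c2cc(/C=C/C(=O)c3ccc(OC)c(OC)c3)[nH]n2)cc1` gives 70%, a number within the scatter of compound 1. For the measured compounds named here, compound 3 `COc1ccc(-c2cc(/C=C/C(=O)c3ccc(N)cc3)[nH]n2)cc1OC` gives 87%, and the only single-place step measured, a number 21 percentage points higher from compound 1 to compound 3 (beyond the scatter), concerns a methoxy group on the other aromatic ring and so does not bear on the change now considered.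

Compound 4 `COc1ccc(C(=O)/C=C/c2cc(-c3cc(OC)c(OC)c(OC)c3)n[nH]2)cc1` differs from compound 1 in one place: methoxy in place of amino on an aromatic carbon. Going by the values given here, no measured step follows this exact change. The nearest hint is compound 2, which carries methoxy groups in place of the amino group and other methoxy groups elsewhere and stays within the scatter of compound 1. On this basis a step of a number 6 percentage points higher from compound 1 to compound 4 (within the scatter) is expected, that is, nothing clearly beyond the scatter. Compound 4 is therefore estimated at 72%, with a range from 55% to 90%.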

Compound 4, a percentage reported as activity, at one concentration (the size of the read-out at that concentration, not a potency): 78%
Estimate against measurement, compound 4: 6 percentage points below; low and high end bracket the measured number.
By their numbers in this assay, from the lowest: compounds 1, 2, 4 and 3 (each within the scatter of the next, the first and the last beyond it).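

Placing 4-methoxyphenyl where compound 1 carries 4-aminophenyl gives the first direct reading of this change in this assay and yields a number 12 percentage points higher from compound 1 to compound 4 (beyond the scatter) on the shared core. Methoxy is thus not an equivalent replacement for amino at this place in this pair, and the effect at the one concentration tested is modestly weaker. For the compounds shown here, the earlier single-place step concerned a methoxy group on the other aromatic ring, so this result is the first to show that the substituent on the ring bearing the amino group also affects the read-out, although nothing at hand gives a reason for the step.

The compounds shown leave open how a hydroxyl, a dimethylamino or an acetamide group would read at this place. They also leave open whether the same change gives a step of this size when the other aromatic ring carries fewer methoxy groups.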